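This account rests on a few compounds, and the source may have more. Where it says the series, first, only, none or still open, it means among the compounds named here.

In a functional assay on ECa-109 cells (Homo sapiens) for antiproliferative activity, read by MTT assay, with a stated time of 72 h (on this read-out lower numbers stand for stronger inhibition and higher numbers for weaker inhibition), three compounds on a shared core have been measured. Compound 1 `CCCSc1nc(N/N=C/c2cccc(Cl)c2)c2nnn(Cc3ccccc3)c2n1` reads > 64000 nM, and this is a limit of the assay, not a number. Compound 2 `CCCSc1nc(N/N=C(\C)c2ccccc2O)c2nnn(Cc3ccccc3)c2n1` gives 11100 nM, and compound 3 `CCCSc1nc(N/N=C/c2ccc(N(C)C)cc2)c2nnn(Cc3ccccc3)c2n1` gives 20000 nM; these two values lie within the scatter of each other. Compound 4 `CCCSc1nc(N/N=C/c2ccccc2F)c2nnn(Cc3ccccc3)c2n1` differs from compound 3 at a single place: 2-fluorophenyl in place of 4-(dimethylamino)phenyl on a carbon with a double bond to nitrogen. In words, 2-fluorophenyl stands in place of 4-(dimethylamino)phenyl on a carbon with a double bond to nitrogen. The measured step closest to this change is an at least 3.2-fold lower number from compound 1 to compound 3 (0.50 log units; beyond the scatter), which exchanges the same 4-(dimethylamino)phenyl for a 3-chlorophenyl when read in reverse. The step of an at least 5.7-fold lower number from compound 1 to compound 2 (0.76 log units; beyond the scatter) changes the same region and also lies beyond the scatter. Like compound 1, compound 4 carries a halogen on its phenyl ring, so part of the reverse of the first step is expected, moving toward a higher number. The expected change is modest, and it is estimated as a 2.1-fold higher number from compound 3 to compound 4 (0.32 log units; beyond the scatter). For compound 4 the estimated value is 42000 nM, with an expected range of 16000 nM to 90000 nM.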

Compound 4, half-maximal inhibitory concentration: > 64000 nM
Compound 4: no number, only a limit (the forecaster's own chance of this, stated with the estimate: 35%); middle value at least 1.5-fold (0.18 log units) away from the limit.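

In this assay compound 4 reads > 64000 nM, a limit of the assay and not a number, so the 2-fluorophenyl compound now sits at the same limit as the 3-chlorophenyl compound 1: the limit of > 64000 nM in this assay, at which 2 of the 4 values shown sit.

Placing 2-fluorophenyl on the carbon with a double bond to nitrogen, in place of 4-(dimethylamino)phenyl, gives an at least 3.2-fold higher number from compound 3 to compound 4 (0.50 log units; beyond the scatter), and the comparison with the other compound that gives a number shows an at least 5.7-fold higher number from compound 2 to compound 4 (0.76 log units; beyond the scatter). The step between the two halogen compounds cannot be read, since both ends of it are limits.

What the compounds shown leave open is whether a plain phenyl, or a ring carrying a methoxy group or an amine, would give a number in this assay. They also leave open how a longer chain in place of the propyl on sulfur would read.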